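Anilinopyrimidine series: growth inhibition of L02 cells

This account rests on a few compounds, and the source may have more. Where it says the series, first, only, none or still open, it means among the compounds named here.

Measured so far:
- compound 1, `Cc1ccccc1Nc1nc(NCc2ccncc2)ncc1Cl`: > 100000 nM
- compound 2, `Cc1ccccc1Nc1nc(Nc2ccc(N3CCCCC3)cn2)ncc1Cl`: 42400 nM
- compound 3, `CN1CCN(c2ccc(Nc3ncc(Cl)c(NCc4ccccc4)n3)nc2)CC1`: 20300 nM

All three were run in an ADME assay on L02 cells (Homo sapiens) for inhibition, read by CCK-8 assay, with a stated time of 48 h; on this read-out higher numbers stand for weaker inhibition of growth and lower numbers for stronger inhibition of growth. For compound 1 the value > 100000 nM is a limit of this assay, not a number. Compound 2 gives 42400 nM in this assay. Compound 3 gives 20300 nM in this assay, the lowest of the two numbers obtained; the gap to compound 2 lies beyond the usual scatter. The limit sits at the limit of > 100000 nM in this assay, at which 1 of the 3 values shown sits.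

The next compound in the series is compound 4, `CC(C)c1cccc(Nc2nc(Nc3ccc(N4CCN(C)CC4)cn3)ncc2Cl)c1`, not yet measured in this assay. It differs from compound 3 in one place:

3-isopropylphenyl in place of benzyl on a nitrogen on an aromatic ring

Going by the values given here, no pair of measured compounds shows this change on its own, so there is no measured step to lean on. The two numbers and the one limit so far all sit in the weak range of this assay, and the shared core carries forward unchanged. The expected step is a 1.5-fold lower number from compound 3 to compound 4 (0.16 log units; within the scatter). Compound 4 is estimated at 14000 nM in this assay, with a range from 5000 nM to 45000 nM.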

Compound 4, concentration for 50% growth inhibition: 12500 nM
Compound 4: middle estimate off by 1.1-fold (0.05 log units), on the high side; the measured number falls inside the stated range.
By their numbers in this assay, from the lowest: compounds 4 and 3 (each within the scatter of the next); then compound 2. At a limit, above all of these: compound 1.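

Working notes on the position on a nitrogen on an aromatic ring: in this assay, 3-isopropylphenyl in place of benzyl gives a 1.6-fold lower number from compound 3 to compound 4 (0.21 log units; within the scatter), so this is the first direct reading of a change at this place, and it stays within the scatter. The swap from benzylamino to (3-isopropylphenyl)amino brings in 9 heavy atoms where 7 stood and adds no hydrogen-bond donors, acceptors or net charge, yet compound 3 and compound 4 cannot be told apart on this read-out, so this position has so far accepted the larger carbon-only group without a resolved shift in growth inhibition. No measurement shown gives a reason for this step.

Open, on these data alone, is whether any group at this place can move the number beyond the scatter: an unsubstituted phenyl would separate the effect of the isopropyl from that of the ring itself, and a carboxylic acid or an amine on that ring would test a group that is not carbon-only. Also open, as far as these compounds go, is whether a longer chain, such as phenethyl, on the same nitrogen would read any differently from benzyl in this assay.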